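The compounds below may be only part of what the source reports. "The series", "measured", "known", "first", "only" and "open" are said of these compounds alone.

Measured compounds: compound 1 `O=C(Nc1cccc(-c2oc3cc(-c4ccc(F)cc4)ccc3c(=O)c2O)c1)c1ccc(F)cc1`, compound 2 `Cc1ccccc1C(=O)Nc1cccc(-c2oc3cc(-c4ccc(F)cc4)ccc3c(=O)c2O)c1`, compound 3 `N#Cc1ccc(C(=O)Nc2cccc(-c3oc4cc(-c5ccc(F)cc5)ccc4c(=O)c3O)c2)cc1`.

In a functional assay on MCF7 cells (Homo sapiens) for antiproliferative activity, read by CCK-8 assay, with a stated time of 72 h (on this read-out higher numbers stand for weaker inhibition and lower numbers for stronger inhibition), compound 1 gives 8590 nM. In this assay compound 2 gives 2280 nM. In this assay compound 3 gives 2660 nM. Compound 3 thus stands second highest of the three numbers; its nearest neighbour is compound 2, with a 1.2-fold higher number from compound 2 to compound 3 (0.07 log units; within the scatter), while the gap to compound 1 is wider, with a 3.2-fold lower number from compound 1 to compound 3 (0.51 log units; beyond the scatter).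

Compound 4 is `O=C(Nc1cccc(-c2oc3cc(-c4ccc(F)cc4)ccc3c(=O)c2O)c1)c1ccc(-c2ccccc2)cc1`. It differs from compound 3 in one place: phenyl in place of cyano on an aromatic carbon. For the measured compounds named here, no measured step replaces a cyano group by a phenyl ring, so nothing bears on this change directly. The two steps measured on the amide aryl ring, a 3.8-fold lower number from compound 1 to compound 2 (0.58 log units; beyond the scatter) and a 3.2-fold lower number from compound 1 to compound 3 (0.51 log units; beyond the scatter), each swapped one substituent for another and each gave a modest move, and the two substituted compounds sit within the scatter of each other, as a 1.2-fold higher number from compound 2 to compound 3 (0.07 log units; within the scatter) shows. That gives no direction for a phenyl entering at the place the cyano group leaves. The expectation is therefore a step within the scatter, a 1.1-fold higher number from compound 3 to compound 4 (0.05 log units; within the scatter), and compound 4 is estimated at 3000 nM, with a range from 1000 nM to 9000 nM.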

Compound 4, half-maximal inhibitory concentration: 38500 nM
The estimate for compound 4 lay 13-fold (1.11 log units) below the measured number; measured number outside the range, above it.
By their numbers in this assay, from the lowest: compounds 2 and 3 (each within the scatter of the next); then compound 1; then compound 4.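

In this assay, the place para to a large group on the aromatic ring of the amide carbonyl is not indifferent to its substituent: earlier changes on this ring gave modest steps at most, whereas a 14-fold higher number from compound 3 to compound 4 (1.16 log units; beyond the scatter) is a large step towards weaker inhibition. The move from fluoro to phenyl at the same place points the same way, though less far, with a 4.5-fold higher number from compound 1 to compound 4 (0.65 log units; beyond the scatter); together with a 17-fold higher number from compound 2 to compound 4 (1.23 log units; beyond the scatter), this leaves compound 4 as the weakest of the four, so the 4-phenylphenyl amide is the only aryl group shown that takes the series clearly beyond compound 1. Nothing available on these compounds accounts for the loss, so the result stands as an observation only.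

From the compounds shown here alone, whether the loss belongs to an aromatic ring at this place as such remains open, since a saturated ring such as cyclohexyl, a pyridyl ring or a short chain such as methoxy could be read against phenyl only if compared on the same core. Equally open, going by these compounds, is how an amine or a carboxylic acid at this place would compare with the nitrile of compound 3.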